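Vero cytotoxicity of ester and sulfonate analogues in the series

This account rests on a few compounds, and the source may have more. Where it says the series, first, only, none or still open, it means among the compounds named here.

Measured so far:
compound 1 `O=c1cc(N2CCN(CC3CCC(OS(=O)(=O)c4cccnc4)CC3)CC2)sc2c([N+](=O)[O-])cc(C(F)(F)F)cc12` — > 64 ug/mL, a limit of the assay, not a number
compound 2 `COc1ccc(C(=O)OC2CCC(CN3CCN(c4cc(=O)c5cc(C(F)(F)F)cc([N+](=O)[O-])c5s4)CC3)CC2)cc1` — > 64 ug/mL, likewise only a limit
compound 3 `O=C(OC1CCC(CN2CCN(c3cc(=O)c4cc(C(F)(F)F)cc([N+](=O)[O-])c4s3)CC2)CC1)c1cccc(C(F)(F)F)c1` — > 64 ug/mL, again only a limit

In an ADME assay on Vero cells (Chlorocebus sabaeus) for cytotoxicity, read by MTT assay, with a stated time of 48 h (on this read-out higher numbers stand for weaker inhibition and lower numbers for stronger inhibition), compound 3 therefore stands at the assay limit, with no number to compare. The steps a step that the two limits leave unreadable from compound 1 to compound 2, a step that the two limits leave unreadable from compound 1 to compound 3 and a step that the two limits leave unreadable from compound 2 to compound 3 are all unreadable because of the limit of > 64 ug/mL in this assay, at which 3 of the 3 values shown sit. Compound 4 `O=C(OC1CCC(CN2CCN(c3cc(=O)c4cc(C(F)(F)F)cc([N+](=O)[O-])c4s3)CC2)CC1)c1ccc2c(c1)OCC2` is not yet measured; it differs from compound 3 by a group of 9 heavy atoms (8 carbon, 1 oxygen; one five-membered non-aromatic ring with 1 hetero atom, one six-membered aromatic ring of carbon only) in place of a group of 10 heavy atoms (7 carbon, 3 fluorine; one six-membered aromatic ring of carbon only), on a carbonyl carbon. The step bearing most directly on it is a step that the two limits leave unreadable from compound 2 to compound 3, a change of the aryl on the carbonyl carbon, which gave no readable size. With no directional information, no step beyond the scatter is expected in this assay, and a further limit is the likely outcome. Compound 4 is expected at 90 ug/mL (range 45 ug/mL to 200 ug/mL), an expected step that the limit leaves unreadable from compound 3 to compound 4.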

Compound 4, half-maximal inhibitory concentration: > 64 ug/mL
Compound 4: a limit, no number (the forecaster's own chance of this, stated with the estimate: 85%); the middle value does not contradict the limit.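

No step among compound 1, compound 2, compound 3 and compound 4 can be read in this assay, because all four give only a limit: the limit of > 64 ug/mL in this assay, at which 4 of the 4 values shown sit.

From the compounds shown here alone, whether any change of the group on the carbonyl carbon or the oxygen alters the read-out remains open.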